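Trifluoromethyl for Methoxy: What Compound 4 Might Show

The source may hold more compounds than are shown below. What is called first, only, known or untested is meant among the compounds shown, and "the series" means these compounds.

Four compounds share one core, and three of them have been measured in a functional assay on MDA-MB-231 cells (Homo sapiens) for antiproliferative activity, with a stated time of 4 days; a lower number here means a stronger inhibitor, a higher number a weaker inhibitor. Compound 1 `CCCCc1ccc2[nH]c(-c3ccc(OC)cc3)c(/C=N/NC(=O)c3ccc(OC)cc3)c2c1` gives 61 nM in this assay. Compound 2 `CCCCc1ccc2[nH]c(-c3ccc(C(F)(F)F)cc3)c(/C=N/NC(=O)c3ccc(OC)cc3)c2c1` differs from compound 1 by a single change, (trifluoromethyl in place of methoxy on an aromatic carbon), and in this assay compound 2 gives 284 nM. That change produced a 4.7-fold higher number from compound 1 to compound 2 (0.67 log units; beyond the scatter), so the member of the pair carrying trifluoromethyl is the weaker inhibitor.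

Compound 3 `CCCCc1ccc2[nH]c(-c3ccc(OC)cc3)c(/C=N/NC(=O)c3ccncc3)c2c1` has a different group on the carbonyl carbon; its core differs from the core of compound 1 by pyridin-4-yl in place of 4-methoxyphenyl on a carbonyl carbon. In this assay compound 3 gives 29 nM, which is a 2.1-fold lower number from compound 1 to compound 3 (0.32 log units; beyond the scatter). Its steps to both other measured compounds lie beyond the scatter, so compound 3 is the strongest inhibitor of the three.

Compound 4 `CCCCc1ccc2[nH]c(-c3ccc(C(F)(F)F)cc3)c(/C=N/NC(=O)c3ccncc3)c2c1` has not been measured. It differs from compound 3 by trifluoromethyl in place of methoxy on an aromatic carbon, and this is the same change, at the same place, as that from compound 1 to compound 2. For the measured compounds named here, only one example of this change has been measured, so the expectation rests on it carrying over unchanged onto the core of compound 3. The step from compound 3 to compound 4 is expected to be a 4.5-fold higher number from compound 3 to compound 4 (0.65 log units; beyond the scatter), because the same change gave a 4.7-fold higher number from compound 1 to compound 2 (0.67 log units; beyond the scatter). Compound 4 is therefore estimated at 130 nM in this assay, with a likely range from 50 nM to 350 nM.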

Compound 4, half-maximal inhibitory concentration: 94 nM
For compound 4 the middle estimate is 1.4-fold (0.14 log units) above the measured one; low and high end bracket the measured number.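

Now that compound 4 has been measured, trifluoromethyl in place of methoxy gives a 3.2-fold higher number from compound 3 to compound 4 (0.51 log units; beyond the scatter) in this assay, so the change again goes with a weaker inhibitor, and its two measured examples agree: the same change on two cores in this assay, a 4.7-fold higher number (0.67 log units; beyond the scatter) from compound 1 to compound 2 and a 3.2-fold higher number (0.51 log units; beyond the scatter) from compound 3 to compound 4, 1.4-fold (0.16 log units) apart, within the scatter of two such steps

The other change, pyridin-4-yl in place of 4-methoxyphenyl on the carbonyl carbon, gives a 3.0-fold lower number from compound 2 to compound 4 (0.48 log units; beyond the scatter), so it goes with a stronger inhibitor whichever group the aromatic carbon carries, and here too the two examples agree: the same change on two cores in this assay, a 2.1-fold lower number (0.32 log units; beyond the scatter) from compound 1 to compound 3 and a 3.0-fold lower number (0.48 log units; beyond the scatter) from compound 2 to compound 4, 1.4-fold (0.16 log units) apart, within the scatter of two such steps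

Within these four compounds, then, each change has about the same size and direction on either core, and no compound goes against this, but two pairs in one assay do not show that the changes would carry over onto a more different core, and they do not explain why either change acts as it does.

The compounds shown leave open whether other groups in place of methoxy, such as a chlorine atom, a nitrile or an amine, would follow the same course. They also leave open what a carboxylic acid on the carbonyl carbon, or a shorter or longer chain in place of the butyl chain, would do.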